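Swapping the Amine Ring at the End of the Ether Chain

The source may report more compounds than this note shows. Statements on the series, on what has been measured and on what is new or still open speak of the compounds shown alone.

Two compounds share one core and differ only in the ring at the end of the chain. In an assay on cerebellum for displacement of a labelled ligand from histamine H1 receptor (Cavia porcellus), read by scintillation counting, with a stated time of 60 min (a lower number here means a stronger inhibitor, a higher number a weaker inhibitor), compound 1 `CN1CCc2ccc(OCCCN3CCCC3)cc2C1=O` gives 39 nM, while compound 2 `CN1CCN(CCCOc2ccc3c(c2)C(=O)N(C)CC3)CC1` gives 706 nM, the higher of the two numbers. Among the measured compounds shown here, the one measured step, an 18-fold higher number from compound 1 to compound 2 (1.26 log units; beyond the scatter), shows that the ring in this place can move the number a great deal. Compound 3 `CN1CCc2ccc(OCCCN3CCC(=O)CC3)cc2C1=O` is the next variant: 4-oxopiperidin-1-yl in place of 4-methylpiperazin-1-yl on a saturated chain carbon, three bonds along the chain from an oxygen on an aromatic ring. For the measured compounds named here, no measured step tests this 4-oxopiperidin-1-yl ring, so the direction rests on a loose analogy: the ring of compound 1 gave the lower number, and a single-nitrogen ring may sit nearer to it than to compound 2. The expected step is a 3.5-fold lower number from compound 2 to compound 3 (0.55 log units; beyond the scatter), toward a lower number. Compound 3 is therefore estimated at 200 nM, within a range of 50 nM to 800 nM.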

Compound 3, inhibition constant: 176 nM
For compound 3 the middle estimate is 1.1-fold (0.06 log units) above the measured one, within the range that was stated.
By their numbers in this assay, from the lowest: compound 1; then compound 3; then compound 2.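

Two six-membered rings with the same count of heavy atoms and of hydrogen-bond acceptors are still told apart at this position: replacing 4-methylpiperazin-1-yl with 4-oxopiperidin-1-yl gives a 4.0-fold lower number from compound 2 to compound 3 (0.60 log units; beyond the scatter) in this assay. The new ring does not match pyrrolidin-1-yl, however, with a 4.5-fold higher number from compound 1 to compound 3 (0.65 log units; beyond the scatter), so the five-membered ring of compound 1 keeps the lowest number of the series. Nothing available explains either step.

The change from compound 1 to compound 3 alters the ring size and adds a carbonyl at once, so the two changes cannot be separated here. A plain piperidin-1-yl ring would bear on that question, while a morpholin-4-yl ring or an open dimethylamino group would show how far the trend extends.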